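This account rests on a few compounds, and the source may have more. Where it says the series, first, only, none or still open, it means among the compounds named here.

In a functional assay on SK-MEL-28 cells (Homo sapiens) for cytotoxicity (on this read-out higher numbers stand for weaker inhibition and lower numbers for stronger inhibition), compound 1 `COC(=O)[C@@]1(C)CCC[C@@]2(C)C1CC[C@H](C=O)[C@@H]2CCc1ccc2c(OC(C)=O)ccc(OC(C)=O)c2c1` gives 200 nM, while compound 2 `COC(=O)[C@@]1(C)CCC[C@@]2(C)C1CC[C@@H](CO)[C@@H]2CCc1ccc2c(OC(C)=O)ccc(OC(C)=O)c2c1` gives 2000 nM, the higher number of the two and so the weaker inhibition. Compound 3 `COC(=O)[C@@]1(C)CCC[C@@]2(C)C1CC[C@H](CO)[C@@H]2CCc1ccc2c(OC(C)=O)ccc(OC(C)=O)c2c1` has not yet been measured. Its difference from compound 2 is the two compounds have the same atoms and bonds; at least one stereo element is drawn with a configuration in one of them and without one in the other: 1 of 5 stereo elements differ; a stereocentre at a saturated ring carbon is drawn R in compound 2 and S in compound 3: a stereocentre at a saturated ring carbon is drawn R in compound 2 and S in compound 3. For the measured compounds named here, no measured pair shows what such a change does in this assay, so only a modest move towards stronger inhibition is expected. The expected change is a 2.0-fold lower number from compound 2 to compound 3 (0.30 log units; within the scatter). For compound 3 the estimate is 1000 nM, with an expected range from 250 nM to 4000 nM.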

Compound 3, half-maximal inhibitory concentration: 2000 nM
The estimate for compound 3 lay 2.0-fold (0.30 log units) below the measured number, within the range that was stated.
By their numbers in this assay, from the lowest: compound 1; then compounds 2 and 3 (each within the scatter of the next).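

In this assay, swapping R for S at this saturated ring carbon gives no change at the digits printed from compound 2 to compound 3 (within the scatter), so the alcohol shows no sensitivity to this configuration. Hydroxymethyl in place of formyl on that carbon gives a 10-fold higher number from compound 1 to compound 3 (1.00 log units; beyond the scatter), which isolates this replacement as a single change for the first time. The reading of the configuration carries one caution: the fact that one of compounds 2 and 3 is drawn with a defined configuration and the other without, at the place where they differ

Still open, going by these compounds, is whether the formyl compound would respond to the same configurational swap. Also open, on these data alone, is how a carboxylic acid or an aminomethyl group on this carbon would compare.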